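From Fluoro to Chloro on an Aromatic Carbon

The source may report more compounds than this note shows. Statements on the series, on what has been measured and on what is new or still open speak of the compounds shown alone.

Three compounds sharing one core are followed here in an ADME assay on HEK293 cells (Homo sapiens) for cytotoxicity, read by MTT assay, with a stated time of 24 h; a higher number here means a weaker inhibitor, a lower number a stronger inhibitor. Going by the values given here, compound 1 `Cn1c(-c2cccc(Cl)c2Cl)nc2cc(-c3nc(-c4ccccc4Cl)no3)ccc21` gives 355 ug/mL, the only exact number so far. Compound 2 `Cn1c(-c2cccc(Cl)c2F)nc2cc(-c3nc(-c4ccc(Cl)cc4)no3)ccc21` reads > 500 ug/mL in this assay, and this is a limit of the assay, not a number. Compound 2 therefore has no exact position on the scale, and the two compounds cannot be ranked with confidence.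

Compound 3 `Cn1c(-c2cccc(Cl)c2Cl)nc2cc(-c3nc(-c4ccc(Cl)cc4)no3)ccc21` is reached from compound 2 by one exchange: chloro in place of fluoro on an aromatic carbon. Chloro replaces fluoro on an aromatic carbon, turning the 3-chloro-2-fluorophenyl into a 2,3-dichlorophenyl. Among the compounds with values here, no measured pair shows this exchange on its own, so the expectation has little to rest on. The best anchor is compound 1 at 355 ug/mL, which suggests that a number within reach of the assay is plausible. The estimated step of an at least 1.1-fold lower number from compound 2 to compound 3 (0.04 log units; that floor lies within the scatter) is expected to be small, towards a lower number if anything, and not beyond the scatter. For compound 3 the expected value is 450 ug/mL, with an estimated range from 250 ug/mL to 800 ug/mL.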

Compound 3, half-maximal inhibitory concentration: > 500 ug/mL
Compound 3 gave a limit, no number; the forecaster's own chance of this, stated with the estimate: 45%; middle value at least 1.1-fold (0.04 log units) from the limit.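

In this assay compound 3 reads > 500 ug/mL, which is a limit of the assay and not a number. The exchange of fluoro for chloro at this position, ortho to a chloro group, therefore yields no exact value, and the step between the two compounds cannot be read, with a limit at both ends: the limit of > 500 ug/mL in this assay, at which 2 of the 3 values shown sit.

Going by these compounds alone, what compound 3 adds is a comparison with compound 1, the only compound here with an exact number: 4-chlorophenyl in place of 2-chlorophenyl on an aromatic carbon gives an at least 1.4-fold higher number from compound 1 to compound 3 (0.14 log units; that floor lies within the scatter), a floor that does not clearly separate the two compounds.

Where compound 2 and compound 3 truly stand on the scale remains open, and with it whether fluoro and chloro differ at this position at all. Also open is how the assay would read with an amine or a carboxylic acid at this position on the ring, since the compounds shown carry only halogens there.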